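Phenoxyacetic acid series: chloro replacing methylsulfonyl

A few compounds are considered here, and "the series" means these few. Any claim that something is new, unique, unknown or untested is made for them only; others in the source may bear on it.

Measured compounds and their numbers in an assay on CHO cells for displacement of a labelled ligand from prostaglandin D2 receptor 2 (Homo sapiens), read by scintillation counting; on this read-out higher numbers stand for weaker inhibition and lower numbers for stronger inhibition:
Compound 1 `CN(C)C(=O)c1ccc(C#Cc2cc(Cl)ccc2OCC(=O)O)cc1` gives 55 nM.
Compound 2 `CS(=O)(=O)c1ccc(C#Cc2cc(Cl)ccc2OCC(=O)O)cc1` gives 86 nM.
Compound 3 `CCCS(=O)(=O)c1cccc(C#Cc2cc(F)ccc2OCC(=O)O)c1` gives 65 nM.

Compound 2 has the highest of the three numbers, but its gap to compound 3 and to compound 1 both lie within the scatter, so the three cannot be ordered on these data. Within the data shown here, the only single-point step measured so far, a 1.6-fold higher number from compound 1 to compound 2 (0.19 log units; within the scatter), swaps one group on the same aromatic carbon that is now altered again: chloro in place of methylsulfonyl on an aromatic carbon gives compound 4 `O=C(O)COc1ccc(Cl)cc1C#Cc1ccc(Cl)cc1`.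

Among the measured compounds shown here, no measured step exchanges a group bearing hydrogen-bond acceptors for a bare halogen at this position, so the step 1>2 is only a loose guide: it shows that one change of group at this site moved the number little. The expectation for compound 4 is therefore a step of a 1.4-fold higher number from compound 2 to compound 4 (0.14 log units; within the scatter) in this assay, slightly toward a higher number, with wide uncertainty. Compound 4 is estimated at 120 nM, in the range 35 nM to 400 nM.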

Compound 4, inhibition constant: 60 nM
Estimate against measurement, compound 4: 2.0-fold (0.30 log units) above, and the stated range covers the measured number.
By their numbers in this assay, from the lowest: compounds 1, 4, 3 and 2 (each within the scatter of the next).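

In this assay, replacing methylsulfonyl and its hydrogen-bond acceptors with chloro, on an aromatic carbon para to a large group, leaves the change within the scatter (a 1.4-fold lower number from compound 2 to compound 4 (0.16 log units; within the scatter)). Replacing dimethylcarbamoyl with chloro at the same place also stays within the scatter (a 1.1-fold higher number from compound 1 to compound 4 (0.04 log units; within the scatter)), so among these three groups this position shows no measurable dependence on keeping a multi-atom substituent, which the earlier exchange between two such groups could not show. No supporting data bear on why these groups read alike.

As far as these compounds go, whether that tolerance extends to an amine, a hydroxyl or a carboxylic acid at this place remains open. Among these compounds, compound 3 differs from compound 4 in more than one place, so it gives no step on this question.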